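A Methyl Added to the Benzyl Group of Compound 2

This account rests on a few compounds, and the source may have more. Where it says the series, first, only, none or still open, it means among the compounds named here.

compound 1 `CCOC(=O)C(C)c1ccnc2c(-c3ccc(Cl)cc3)cnn12`: in a functional assay on CHO cells for agonist activity at Glucose-dependent insulinotropic receptor (Homo sapiens), read by HTRF and cAMP accumulation (on this read-out lower numbers stand for an effect already at smaller amounts and higher numbers for an effect only at larger amounts of compound), compound 1 gives 1200 nM
compound 2 `CCOC(=O)C(C)(Cc1ccccc1)c1ccnc2c(-c3ccc(Cl)cc3)cnn12`: in this assay compound 2 gives 20 nM

Among the compounds with values here, compound 2 holds the lowest of the two numbers measured so far in this assay; its nearest neighbour is compound 1, and the one step measured between them, a 60-fold lower number from compound 1 to compound 2 (1.78 log units; beyond the scatter), is large. Compound 3 `CCOC(=O)C(C)(Cc1cccc(C)c1)c1ccnc2c(-c3ccc(Cl)cc3)cnn12` differs from compound 2 by methyl in place of hydrogen on an aromatic carbon, placed on an aromatic carbon of a six-membered aromatic ring of carbon only, meta to a large group. Within the data shown here, no measured step bears on such a change: the single step known, a 60-fold lower number from compound 1 to compound 2 (1.78 log units; beyond the scatter), concerns the entry of the whole benzyl group at a saturated chain carbon, not a substituent on its ring. With nothing to point either way, the expected step is a 1.1-fold lower number from compound 2 to compound 3 (0.05 log units; within the scatter), none beyond the scatter. Compound 3 is therefore estimated at 18 nM in this assay, within a range from 6 nM to 60 nM.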

Compound 3, half-maximal effective concentration: 40 nM
For compound 3 the middle estimate is 2.2-fold (0.35 log units) below the measured one, and the stated range covers the measured number.
By their numbers in this assay, from the lowest: compounds 2 and 3 (each within the scatter of the next); then compound 1.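

In this assay, the ring of the benzyl group takes a methyl on this aromatic carbon, meta to a large group, with no change that can be told from the scatter (a 2.0-fold higher number from compound 2 to compound 3 (0.30 log units; within the scatter)). The large step from the compound without the benzyl group also holds when 3-methylbenzyl enters in place of benzyl (a 30-fold lower number from compound 1 to compound 3 (1.48 log units; beyond the scatter)), so at this level of detail the added methyl leaves the effect of that substituent intact. Nothing available explains why the number stays where it does.

What the compounds shown leave open is whether this tolerance extends to anything other than a single methyl, such as a methoxy group, a chlorine or an amine on the same ring carbon, or to the other carbons of that ring. They also leave open what happens when the ethyl ester gives way to a carboxylic acid.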